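Swapping a chlorine for two fluorines on a cyclohexyl ring

The compounds below may be only part of what the source reports. "The series", "measured", "known", "first", "only" and "open" are said of these compounds alone.

Measured compounds:
compound 1, `C[C@H]1CC[C@H](C(=O)N(c2cc(C#CC3(C(F)(F)F)CC3)sc2C(=O)O)[C@H]2CC[C@H](Oc3ccc(=O)[nH]n3)CC2)CC1` — in an ADME assay on MT4 cells (Homo sapiens) for cytotoxicity, with a stated time of 5 days (on this read-out lower numbers stand for higher toxicity in this test and higher numbers for lower toxicity in this test), compound 1 gives > 20000 nM, which is a limit of the test rather than a number.
compound 2, `CC(C)N(c1cc(C#CC(C)(C)C)sc1C(=O)O)C(=O)[C@H]1CC[C@H](Cl)CC1` — in this assay compound 2 gives > 20000 nM, likewise a limit and not a number.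

Compound 2 therefore stands where the test stops reporting, and compound 1 sits at the same point (the limit of > 20000 nM in this assay, at which 2 of the 2 values shown sit). Within the data shown here, no compound has been measured that differs from compound 2 in only one place, so no measured step exists to lean on. Compound 3, `CC(C)N(C(=O)C1CCC(F)(F)CC1)c1cc(C#CC(C)(C)C)sc1C(=O)O`, differs from compound 2 in one change: 4,4-difluorocyclohexyl in place of 4-chlorocyclohexyl on a carbonyl carbon. With both known values resting at the limit, no shift beyond the usual scatter in this assay is expected from compound 2 to compound 3, and the step that the limit leaves unreadable from compound 2 to compound 3 is only an estimate. Compound 3 is estimated at 30000 nM, most likely again reported as a limit, with a range from 15000 nM to 80000 nM.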

Compound 3, half-maximal cytotoxic concentration: > 20000 nM
Compound 3 was reported as a limit; the forecaster's own chance of this, stated with the estimate: 85%; the middle value is on the limit's open side.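

In this assay compound 3 gives > 20000 nM, again a limit and not a number. The change from compound 2 to compound 3 therefore gives no readable step: the limit of > 20000 nM in this assay, at which 3 of the 3 values shown sit. The compounds shown leave open how far each lies from that limit, and whether 4-chlorocyclohexyl and 4,4-difluorocyclohexyl differ at all in this assay.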